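This account rests on a few compounds, and the source may have more. Where it says the series, first, only, none or still open, it means among the compounds named here.

Measured compounds:
Compound 1, `Fc1cccc2c1CC2CN1CCN(c2cccc3c2OCCO3)CC1`: 0.63 mg/kg
Compound 2, `Clc1cccc2c1CC2CCN1CCN(c2cccc3c2OCCO3)CC1`: 1.25 mg/kg

In a functional assay on the whole organism for antagonist activity, with Rattus norvegicus as the target (a lower number here means that less compound is needed, a higher number that more compound is needed for the effect), compound 1 gives 0.63 mg/kg. Compound 2 gives 1.25 mg/kg in this assay. Going by the values given here, the two numbers lie within the usual scatter of each other, so the data do not separate compound 1 from compound 2; no step between them is given, and the account says no more about their pair than what the two values show.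

Compound 3, `c1ccc2c(c1)CC2CN1CCN(c2cccc3c2OCCO3)CC1`, is the one still to be measured. It differs from compound 1 in one place: hydrogen in place of fluoro on an aromatic carbon.

Among the compounds with values here, with only two measured compounds and no step between them, there is nothing in the numbers that tells how the loss of the fluoro will read out. The step from compound 1 to compound 3 is expected to be small, at most a modest rise in the minimum effective dose, and quite possibly none beyond the scatter, a 1.6-fold higher number from compound 1 to compound 3 (0.20 log units; within the scatter). Compound 3 is therefore estimated to give 1 mg/kg in this assay, with a range from 0.3 mg/kg to 3 mg/kg.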

Compound 3, minimum effective dose: 0.63 mg/kg
Estimate against measurement, compound 3: 1.6-fold (0.20 log units) above, and the stated range covers the measured number.
By their numbers in this assay, from the lowest: compounds 1, 3 and 2 (each within the scatter of the next).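

In this assay, hydrogen in place of fluoro on an aromatic carbon gives no change at the digits printed from compound 1 to compound 3 (within the scatter). Going by these compounds alone, this is the first reading at this position, ortho to a fused ring and meta to a fused ring, and it shows that the minimum effective dose of the shared core does not depend on the fluoro there: the compound without it cannot be told apart from the one with it. Nothing at hand bears on why the two compounds read alike.

The compounds shown leave open whether a methoxy group, a nitrile or an amine on this same aromatic carbon would also leave the minimum effective dose where it stands. They also leave open whether a trifluoromethyl group there would move it beyond the scatter.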